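This account rests on a few compounds, and the source may have more. Where it says the series, first, only, none or still open, it means among the compounds named here.

Measured so far:
compound 1 `COc1cc(-c2nn(-c3ccc(NC(=O)Nc4ccc(Cl)c(Cl)c4)cc3)cc2-c2ccncc2)ccc1Cl` — 2870 nM
compound 2 `COc1cc(-c2nn(-c3ccc(NC(=O)Nc4ccc(Cl)c(C(F)(F)F)c4)cc3)cc2-c2ccncc2)ccc1Cl` — 1600 nM

Both numbers come from a functional assay on MDA-MB-435 cells (Homo sapiens) for antiproliferative activity, read by sulforhodamine B assay, with a stated time of 48 h; a lower number here means a stronger inhibitor, a higher number a weaker inhibitor. Compound 2 carries the lower of the two, but the step of a 1.8-fold lower number from compound 1 to compound 2 (0.25 log units; within the scatter) is within the scatter, so the two stand together. Compound 3 `COc1cc(-c2nn(-c3ccc(NC(=O)c4ccc(Cl)c(Cl)c4)cc3)cc2-c2ccncc2)ccc1Cl` differs from compound 2 by 3,4-dichlorophenyl in place of (4-chloro-3-(trifluoromethyl)phenyl)amino on a carbonyl carbon. For the measured compounds named here, no measured step bears on this change: the single step, a 1.8-fold lower number from compound 1 to compound 2 (0.25 log units; within the scatter), concerns trifluoromethyl in place of chloro and leaves the carbonyl link untouched. With no guide in the data, the direction is uncertain, and a modest weakening is assumed rather than shown. Compound 3 is therefore expected at 5000 nM, between 1500 nM and 16000 nM, a step of a 3.1-fold higher number from compound 2 to compound 3 (0.49 log units; beyond the scatter).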

Compound 3, half-maximal inhibitory concentration: 7130 nM
Beside the measured number, compound 3's estimate is 1.4-fold (0.15 log units) below it; measured number inside the range.
By their numbers in this assay, from the lowest: compounds 2 and 1 (each within the scatter of the next); then compound 3.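

For the compounds shown here, with 3,4-dichlorophenyl on the carbonyl carbon in place of (3,4-dichlorophenyl)amino, this assay gives a 2.5-fold higher number from compound 1 to compound 3 (0.40 log units; beyond the scatter), the first step beyond the scatter. Against the trifluoromethyl-bearing amino group the same kind of change gives a 4.5-fold higher number from compound 2 to compound 3 (0.65 log units; beyond the scatter), so both amino groups compare favourably with direct attachment of the ring to the carbonyl carbon. No data at hand account for these steps. Open, going by these compounds, is how a methyl group on that nitrogen or a methylene link in its place would compare. Also open, on these data alone, is whether trifluoromethyl on the directly attached ring would change the picture.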